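A few compounds are considered here, and "the series" means these few. Any claim that something is new, unique, unknown or untested is made for them only; others in the source may bear on it.

In an assay on isolated protein for inhibition of solute carrier family 22 member 12 (Homo sapiens), tested at 3 uM (on this read-out higher numbers stand for more inhibition at the one concentration tested (going by the name of the read-out) and lower numbers for less inhibition), compound 1 `N#Cc1cc(C(=O)N2CC=CC2)cc(I)c1O` gives 79%, while compound 2 `Cc1cc(C(=O)N2CC=CC2)cc(C#N)c1O` gives 25%, the lowest of the two numbers in this assay, and the step of a number 54 percentage points lower from compound 1 to compound 2 (beyond the scatter) came with methyl in place of iodo on an aromatic carbon. Compound 3 `CC(C)(C)c1cc(C(=O)N2CC=CC2)cc(C#N)c1O` is the next compound to be measured; it differs from compound 2 by tert-butyl in place of methyl on an aromatic carbon. Within the data shown here, no measured step replaces a methyl by a tert-butyl, so only the iodo-to-methyl step offers guidance: it was large and downward when the bigger group left. On that single observation compound 3 is expected to recover part of the lost inhibition in this assay, with a step of a number 17 percentage points higher from compound 2 to compound 3 (beyond the scatter) expected, though the uncertainty is wide. The estimate for compound 3 in this assay is therefore 42%, with a range from 15% to 70%.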

Compound 3, a percentage reported as inhibition, at one concentration (the size of the read-out at that concentration, not a potency): 92%
The estimate for compound 3 lay 50 percentage points below the measured number; measured number above the stated range.
By their numbers in this assay, from the lowest: compound 2; then compound 1; then compound 3.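

In this assay, the position ortho to the hydroxy group proves not to depend on iodo: tert-butyl in place of methyl gives a number 67 percentage points higher from compound 2 to compound 3 (beyond the scatter), so a group with no halogen restores the inhibition that was lost with methyl. Tert-butyl also goes past iodo, with a number 13 percentage points higher from compound 1 to compound 3 (beyond the scatter), which makes methyl the low point of the three groups at this position rather than iodo a unique optimum. Nothing available explains why these groups rank in this order.

From the compounds shown here alone, three groups cannot show how inhibition changes between methyl and tert-butyl, so it remains open whether ethyl or isopropyl would fall nearer compound 2 or compound 3. Going by these compounds, it is also open whether a phenyl ring or a carboxylic acid at this position would keep the inhibition.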